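Trifluoroalkyl to trifluorobenzyl on the indazole-bearing series

The compounds below may be only part of what the source reports. "The series", "measured", "known", "first", "only" and "open" are said of these compounds alone.

Within the data shown here, compound 2 `CC1(C)C(=O)Nc2nc(-n3nc(CCC(F)(F)F)c4ccccc43)nc(N)c21` is the weakest of the three measured members: in an assay on CHO cells for activation of soluble guanylate cyclase alpha1/beta1 complex (Homo sapiens), read by cGMP accumulation (on this read-out lower numbers stand for an effect already at smaller amounts and higher numbers for an effect only at larger amounts of compound), compound 2 gives 882000 nM. The nearest neighbour is compound 1 `CC1(C)C(=O)Nc2nc(-n3nc(Cc4ccccc4F)c4cc(Cl)ccc43)nc(N)c21`, which in this assay gives 18000 nM; the gap between them is beyond the scatter. Compound 3 `COC(=O)N(C)c1c(N)nc(-n2nc(Cc3ccccc3F)c3cc(F)ccc32)nc1N` stands furthest away and in this assay gives 960 nM, again beyond the scatter relative to compound 2. Among the measured compounds shown here, no pair among the three differs in a single place, so no isolated step can be read from them.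

Compound 4 `CC1(C)C(=O)Nc2nc(-n3nc(Cc4c(F)ccc(F)c4F)c4ccccc43)nc(N)c21` is not yet measured. It differs from compound 2 by 2,3,6-trifluorophenyl in place of 2,2,2-trifluoroethyl on a saturated chain carbon bound to an aromatic carbon. Both measured compounds carrying a benzyl-type group on this carbon, compound 1 and compound 3, return far lower numbers than compound 2, although each also differs from compound 2 elsewhere.

On that basis compound 4 is expected to give 25000 nM in this assay, within 6000 nM to 100000 nM, which would mean an estimated step of a 35-fold lower number from compound 2 to compound 4 (1.55 log units; beyond the scatter), a clear move beyond the scatter toward smaller amounts.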

Compound 4, half-maximal effective concentration: 2000 nM
Compound 4: the middle estimate sits 13-fold (1.10 log units) above what was measured; the whole stated range lies above it.
By their numbers in this assay, from the lowest: compound 3; then compound 4; then compound 1; then compound 2.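

In this assay, this series now has its first comparison that differs in one place only: a 440-fold lower number from compound 2 to compound 4 (2.64 log units; beyond the scatter). With the rest of the structure held constant, 3,3,3-trifluoropropyl to 2,3,6-trifluorobenzyl on this carbon is enough on its own to produce a large step, and it does so with the same number of fluorine atoms in the leaving and entering groups. No measurement available here accounts for the size of this step.

The compounds shown do not separate the contribution of the aromatic ring from that of the fluorine pattern on it. From the compounds shown here alone, a plain benzyl group or a cyclohexylmethyl group at this position would address that question, and whether the step carries over to other cores also remains open.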